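A few compounds are considered here, and "the series" means these few. Any claim that something is new, unique, unknown or untested is made for them only; others in the source may bear on it.

Compound 1 `CC(Sc1nc2c(cnn2C)c(=O)n1-c1ccc(CO)cc1)c1ccccc1`: 600 nM
Compound 2 `COc1cccc(C(C)Sc2nc3c(cnn3C)c(=O)n2-c2ccccc2)c1`: 451 nM

Both compounds were examined in an assay on isolated protein for inhibition of aldehyde dehydrogenase 1A1 (Homo sapiens); a lower number here means a stronger inhibitor, a higher number a weaker inhibitor. Compound 2 stands at one end of the two numbers, and compound 1 lies within the usual scatter of it, so the two cannot be told apart on these data.

Compound 3 `CC(Sc1nc2c(cnn2C)c(=O)n1-c1ccccc1)c1cccc(O)c1` differs from compound 2 by hydrogen in place of methyl on an oxygen on an aromatic ring. For the measured compounds named here, no measured pair in this set shows such a change, so nothing here tells its size. Compound 3 is expected to stay close, with a step of a 1.1-fold higher number from compound 2 to compound 3 (0.04 log units; within the scatter) that does not go beyond the scatter. Compound 3 is therefore estimated at 500 nM, ranging from 150 nM to 1600 nM.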

Compound 3, half-maximal inhibitory concentration: 130 nM
Beside the measured number, compound 3's estimate is 3.8-fold (0.59 log units) above it, and the stated range ends above it.
By their numbers in this assay, from the lowest: compound 3; then compounds 2 and 1 (each within the scatter of the next).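

In this assay, replacing 3-methoxyphenyl with 3-hydroxyphenyl gives a 3.5-fold lower number from compound 2 to compound 3 (0.54 log units; beyond the scatter). This shows that the group on this oxygen matters to the read-out, which compound 1 and compound 2 alone could not reveal, since they differ in more than one place. No available evidence accounts for this step.

From the compounds shown here alone, whether an amine or a carboxylic acid in this place would match the hydroxy group remains open. Also open, going by these compounds, is how a longer chain on the oxygen, such as ethoxy, would compare.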